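The compounds below may be only part of what the source reports. "The series", "measured", "known", "first", "only" and "open" are said of these compounds alone.

Measured so far in an assay on HEK293 cells for displacement of a labelled ligand from metabotropic glutamate receptor 5 (Rattus norvegicus); on this read-out higher numbers stand for weaker inhibition and lower numbers for stronger inhibition:
compound 1 `O=C(Nc1cc(-c2ccccc2)nn1-c1ccccc1)c1ccccc1` — 4180 nM
compound 2 `O=C(Nc1cc(-c2ccccc2)nn1-c1ccccc1)c1cccc([N+](=O)[O-])c1` — 2220 nM

Two compounds share the core and differ only on the aromatic ring attached to the carbonyl carbon. Compound 2 does not separate from compound 1 in this assay: the step of a 1.9-fold lower number from compound 1 to compound 2 (0.27 log units; within the scatter) stays inside the scatter, so the two values count as the same within the precision of this read-out.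

Compound 3 `Cc1ccc(C(=O)Nc2cc(-c3ccccc3)nn2-c2ccccc2)cc1` is not yet measured. Relative to compound 2 the change is 4-methylphenyl in place of 3-nitrophenyl on a carbonyl carbon. Among the measured compounds shown here, no measured pair covers a methyl at this place; the only step on the ring attached to the carbonyl carbon is a 1.9-fold lower number from compound 1 to compound 2 (0.27 log units; within the scatter), which was within the scatter. The data therefore give no ground to expect the 4-methylphenyl compound to move beyond the scatter in either direction.

The expectation for compound 3 in this assay is accordingly a value near those of compound 1 and compound 2, with a step of a 1.6-fold higher number from compound 2 to compound 3 (0.20 log units; within the scatter) expected, and an estimate of 3500 nM in the range from 1200 nM to 10000 nM.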

Compound 3, inhibition constant: 780 nM
Estimate against measurement, compound 3: 4.5-fold (0.65 log units) above; measured number outside the range, below it.
By their numbers in this assay, from the lowest: compound 3; then compounds 2 and 1 (each within the scatter of the next).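

In this assay the ring attached to the carbonyl carbon proves able to move the number beyond the scatter, which the nitro step alone did not show: 4-methylphenyl in place of 3-nitrophenyl gives a clear change (a 2.8-fold lower number from compound 2 to compound 3 (0.45 log units; beyond the scatter)), and the methyl alone gives one of similar standing (a 5.4-fold lower number from compound 1 to compound 3 (0.73 log units; beyond the scatter)). Compound 3 therefore stands apart from both earlier compounds with the lowest number of the three, while compound 1 and compound 2 remain within the scatter of each other, so on this ring the methyl separates where the nitro did not. Nothing measured alongside these numbers speaks to the reason for either step.

From the compounds shown here alone, with a single methyl compound, it remains open whether the step belongs to the methyl itself or to where it sits on the ring, and whether a longer chain such as ethyl, a methoxy group or an amine in that place would keep, extend or lose it. Going by these compounds, all three compounds also carry the same shared core, so it remains open whether the step holds when the other rings change.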